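The compounds below may be only part of what the source reports. "The series", "measured", "known", "first", "only" and "open" are said of these compounds alone.

Compound 1 `Nc1cc(N)c2nc(-c3ccccc3)c(Oc3ccc(Cl)c(Cl)c3)nc2c1`: 10200 nM
Compound 2 `CCOC(=O)[C@H](CCC(=O)O)NC(=O)c1ccc(CNc2nc3cc(N)cc(N)c3nc2-c2ccccc2)cc1`: 26300 nM
Compound 3 `Nc1cc(N)c2nc(-c3ccccc3)c(NCc3ccc(Cl)c(Cl)c3)nc2c1`: 1580 nM

All three were tested in a functional assay on MDA-MB-231 cells (Homo sapiens) for inhibition, read by sulforhodamine B assay, with a stated time of 48 h; a lower number here means a stronger inhibitor of growth, a higher number a weaker inhibitor of growth. Among them compound 3 gives the lowest number, 1580 nM; compound 1 stands nearest, with a number that is higher beyond the scatter, and compound 2 furthest, also beyond the scatter. Compound 3 thus reads as the strongest inhibitor of growth of the three, though neither neighbour differs from it in a single place, so only the bare values can be set side by side.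

Compound 4 `COc1ccc(CNc2nc3cc(N)cc(N)c3nc2-c2ccccc2)cc1OC` has not yet been measured. It differs from compound 3 in one place: 3,4-dimethoxyphenyl in place of 3,4-dichlorophenyl on a saturated chain carbon bound to a nitrogen on an aromatic ring. Nothing measured here shows what such a swap does on the shared core; the closest comparison, compound 2 against compound 3, involves a far larger group and is not a single-point change. The expected step is modest and toward a higher number, with wide uncertainty: a 2.2-fold higher number from compound 3 to compound 4 (0.35 log units; beyond the scatter). Compound 4 is estimated at 3500 nM in this assay, within 1200 nM to 12000 nM.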

Compound 4, concentration for 50% growth inhibition: 11200 nM
Compound 4: the middle estimate sits 3.2-fold (0.51 log units) below what was measured; the measured number falls inside the stated range.
By their numbers in this assay, from the lowest: compound 3; then compounds 1 and 4 (each within the scatter of the next); then compound 2.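

Among the compounds shown here, this is the first change at a single place on the shared core: in this assay, 3,4-dimethoxyphenyl in place of 3,4-dichlorophenyl on a saturated chain carbon bound to a nitrogen on an aromatic ring gives a 7.1-fold higher number from compound 3 to compound 4 (0.85 log units; beyond the scatter). The result shows that the number at this position depends on what the aromatic ring carries, and that here the dichloro-substituted ring, which has no hydrogen-bond acceptors, reads lower than the dimethoxy-substituted ring, which has them. Nothing available accounts for this difference.

From the compounds shown here alone, it remains open how an unsubstituted phenyl, a fluorophenyl or a hydroxyphenyl would read on the same chain carbon, and whether a longer chain would preserve the number of compound 3. Whether the same swap would have a similar effect with the oxygen link of compound 1 is also unresolved.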